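The compounds below may be only part of what the source reports. "The series", "measured", "known", "first", "only" and "open" are said of these compounds alone.

Working notes on a quinoxaline-sulfone series.

Compound 1 `COc1cc(Nc2nc3ccccc3nc2S(=O)(=O)c2ccccc2)cc(OC)c1` is the reference point. In a functional assay on A549 cells (Homo sapiens) for cytotoxicity, read by MTT assay, with a stated time of 72 h (a higher number here means a weaker inhibitor, a lower number a stronger inhibitor), compound 1 gives 70 nM. Compound 2 `Nc1ccc(Nc2nc3ccccc3nc2S(=O)(=O)c2ccccc2)cc1` carries a different group on the ring nitrogen: 4-aminophenyl in place of 3,5-dimethoxyphenyl on a nitrogen on an aromatic ring. In this assay compound 2 gives 12900 nM, a step of a 180-fold higher number from compound 1 to compound 2 (2.27 log units; beyond the scatter). Compound 3 `COc1ccc(S(=O)(=O)c2nc3ccccc3nc2Nc2cc(OC)cc(OC)c2)cc1` differs from compound 1 in the sulfonyl-bound ring only: methoxy in place of hydrogen on an aromatic carbon. In this assay compound 3 gives 12700 nM, a step of a 180-fold higher number from compound 1 to compound 3 (2.26 log units; beyond the scatter). Compound 2 and compound 3 lie within the scatter of each other, so no order between them is claimed.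

Compound 4 `COc1ccc(S(=O)(=O)c2nc3ccccc3nc2Nc2ccc(N)cc2)cc1` is not yet measured. It stands to compound 3 as compound 2 stands to compound 1: 4-aminophenyl in place of 3,5-dimethoxyphenyl on a nitrogen on an aromatic ring. The place lines of the two changes read the same word for word, so this is the same change, made on a core that already carries the methoxy of compound 3 instead of the hydrogen of compound 1.

For the measured compounds named here, the only earlier instance of this change is the step of a 180-fold higher number from compound 1 to compound 2 (2.27 log units; beyond the scatter), made from a strong starting compound. Compound 3 starts from a far higher number, and a second step of the same size would carry compound 4 past the range where a half-maximal concentration is usually resolved in a cell-viability read-out. The expectation is therefore a step of a 3.9-fold higher number from compound 3 to compound 4 (0.60 log units; beyond the scatter), smaller than the earlier one, with a real chance that only a limit is reported. Compound 4 is expected at 50000 nM, between 13000 nM and 200000 nM.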

Compound 4, half-maximal inhibitory concentration: 2990 nM
Compound 4: the middle estimate sits 17-fold (1.22 log units) above what was measured; the measured number lies below the stated range.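

In this assay, 4-aminophenyl in place of 3,5-dimethoxyphenyl on the ring nitrogen gives a step in the opposite direction on the methoxy-bearing core (a 4.2-fold lower number from compound 3 to compound 4 (0.63 log units; beyond the scatter)), so the earlier step does not carry over from the core of compound 1: the same change on two cores in this assay, a 180-fold higher number (2.27 log units; beyond the scatter) from compound 1 to compound 2 and a 4.2-fold lower number (0.63 log units; beyond the scatter) from compound 3 to compound 4, 780-fold (2.89 log units) apart, beyond the scatter of two such steps. Read the other way round, methoxy in place of hydrogen on the sulfonyl-bound ring also reverses direction once 4-aminophenyl is present (a 4.3-fold lower number from compound 2 to compound 4 (0.63 log units; beyond the scatter)), and the two changes therefore do not act independently in these four compounds: the same change on two cores in this assay, a 180-fold higher number (2.26 log units; beyond the scatter) from compound 1 to compound 3 and a 4.3-fold lower number (0.63 log units; beyond the scatter) from compound 2 to compound 4, 780-fold (2.89 log units) apart, beyond the scatter of two such steps. This shows that neither change can be carried from one core to another in this series by simply adding its step, but with one pair of cores per change and a single cell-viability read-out, it does not show why the two changes depend on each other or whether the same holds for other groups.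

The compounds shown leave open whether this dependence is specific to the 3,5-dimethoxyphenyl and 4-aminophenyl groups or extends to other groups on the ring nitrogen, such as a single methoxy-bearing phenyl or a plain phenyl. They also leave open how a fluorine, a nitrile or a carboxylic acid in place of the methoxy on the sulfonyl-bound ring would behave on either core.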